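The source may report more compounds than this note shows. Statements on the series, on what has been measured and on what is new or still open speak of the compounds shown alone.

Measured in a functional assay on MIA PaCa-2 cells (Homo sapiens) for antiproliferative activity, read by MTT assay, with a stated time of 48 h; on this read-out higher numbers stand for weaker inhibition and lower numbers for stronger inhibition:
compound 1 `CCCCCCc1nc(N)n(CC(=O)Nc2ccccc2)c1-c1ccccc1Br` gives 8600 nM
compound 2 `Nc1nc(CC2CCCCC2)c(-c2ccccc2Br)n1CC(=O)Nc1ccccc1` gives 89000 nM
compound 3 `CCCCCCc1nc(N)n(CC(=O)Nc2ccc(C)cc2)c1-c1ccccc1Br` gives 6500 nM

Compound 3 has the lowest number of the three, but the step of a 1.3-fold lower number from compound 1 to compound 3 (0.12 log units; within the scatter) is within the scatter, so compound 1 and compound 3 are not to be ordered against each other. Compound 2 sits well beyond the scatter at a higher number than compound 3.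

Compound 4 `Cc1ccc(Cc2nc(N)n(CC(=O)Nc3ccc(C)cc3)c2-c2ccccc2Br)cc1` differs from compound 3 by 4-methylphenyl in place of pentyl on a saturated chain carbon bound to an aromatic carbon. Among the compounds with values here, only one measured step touches this place: a 10-fold higher number from compound 1 to compound 2 (1.01 log units; beyond the scatter), where a saturated ring replaced the pentyl chain and the number rose sharply. Within the data shown here, the ring entering in compound 4 is aromatic and carries a methyl, so the change is not the same, and no measured pair shows an aromatic ring at this position. Among the measured compounds shown here, still, the one guide available points toward a weaker compound when a ring takes the place of the pentyl, and the expectation leans that way, with wide uncertainty: compound 4 is expected to show the step of a 4.6-fold higher number from compound 3 to compound 4 (0.66 log units; beyond the scatter). Compound 4 is estimated at 30000 nM, with a range from 8000 nM to 120000 nM.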

Compound 4, half-maximal inhibitory concentration: 2900 nM
The estimate for compound 4 lay 10-fold (1.01 log units) above the measured number, outside the stated range (below it).
By their numbers in this assay, from the lowest: compound 4; then compounds 3 and 1 (each within the scatter of the next); then compound 2.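

At the saturated chain carbon bound to an aromatic carbon, a ring in place of pentyl does not always raise the number: in this assay, 4-methylphenyl gives a 2.2-fold lower number from compound 3 to compound 4 (0.35 log units; beyond the scatter), whereas cyclohexyl gave a 10-fold higher number from compound 1 to compound 2 (1.01 log units; beyond the scatter). The rise seen with cyclohexyl therefore does not extend to every ring at this place, and compound 4 goes against any such general reading, with the two ring changes moving the number in opposite directions. Nothing available here accounts for this difference between the two rings.

The two steps start from compounds that differ by methyl in place of hydrogen on an aromatic carbon, so the compounds shown do not set cyclohexyl and 4-methylphenyl against each other on one background, and it remains open whether the opposite directions belong to the rings alone. Also open, from the compounds shown here alone, is whether the methyl on the entering ring matters, which a plain phenyl at this place would address, and how an amine or a carboxylic acid on that ring would read in this assay.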